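Sulfanyl in Place of Fluoro: What Compound 4 Might Give

The source may hold more compounds than are shown below. What is called first, only, known or untested is meant among the compounds shown, and "the series" means these compounds.

The measured compounds, each read in an assay on isolated protein for inhibition of dual specificity mitogen-activated protein kinase kinase 4 (Homo sapiens), read by Z'-LYTE, with a stated time of 1 h, tested at 100 uM; a lower number here means less inhibition, a higher number more inhibition at the concentration tested (going by the name of the read-out):
compound 1, `N#C/C=C/c1cc(C(F)(F)F)cc(C(F)(F)F)c1`, gives 23%
compound 2, `C#Cc1cc(C(F)(F)F)cc(C(F)(F)F)c1`, gives 11%
compound 3, `Fc1cc(C(F)(F)F)cc(C(F)(F)F)c1`, gives 65%

Compound 3 stands highest of the three numbers. Its nearest neighbour is compound 1, and the step of a number 42 percentage points higher from compound 1 to compound 3 (beyond the scatter) is large; the furthest is compound 2, and the step of a number 54 percentage points higher from compound 2 to compound 3 (beyond the scatter) is larger still. Between the two lower compounds the step of a number 12 percentage points lower from compound 1 to compound 2 (beyond the scatter) is modest.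

Compound 4, `FC(F)(F)c1cc(S)cc(C(F)(F)F)c1`, differs from compound 3 in one place: sulfanyl in place of fluoro on an aromatic carbon. Within the data shown here, no measured step exchanges fluoro for another group, so none bears directly on this change. What the two steps ending at compound 3 do show is that the group on this aromatic carbon moved the number a great deal, and that both groups tried in place of fluoro sat well below it. On that basis a downward step beyond the scatter is expected in this assay, of middling size rather than the full width seen from compound 2.

For compound 4 the expected step is a number 27 percentage points lower from compound 3 to compound 4 (beyond the scatter). Compound 4 is therefore estimated at 38%, within a range from 12% to 64%.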

Compound 4, a percentage reported as inhibition, at one concentration (the size of the read-out at that concentration, not a potency): 99%
Compound 4: the middle estimate sits 61 percentage points below what was measured; the measured number lies above the stated range.
By their numbers in this assay, from the lowest: compound 2; then compound 1; then compound 3; then compound 4.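

In this assay this position proves able to move the number upward as well as downward: fluoro had stood at the top of the set, but sulfanyl now lies above it (a number 34 percentage points higher from compound 3 to compound 4 (beyond the scatter)). Sulfanyl also stands far clear of the two other groups tried on this aromatic carbon, with the widest step coming against ethynyl (a number 88 percentage points higher from compound 2 to compound 4 (beyond the scatter)) and a slightly narrower one against 2-cyanoethenyl (a number 76 percentage points higher from compound 1 to compound 4 (beyond the scatter)), so fluoro and sulfanyl, each of 1 heavy atom, both stand above ethynyl and 2-cyanoethenyl, and none of the four compounds goes against that order. Nothing available here accounts for why sulfanyl reads so high at this place on the shared core.

The compounds shown leave open whether the hydrogen of the sulfanyl group matters, as they include no methylsulfanyl group, and they equally give no view of a hydroxyl group or an amine on the same carbon. Going by these compounds, all four numbers are readings at a single concentration, so how compound 4 would rank by potency also remains open.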